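The source may report more compounds than this note shows. Statements on the series, on what has been measured and on what is new or still open speak of the compounds shown alone.

Working notes on the series. Compound 2 `O=C(Nc1ccc(Cl)cc1)Nc1nnc(Sc2ncnc3scc(-c4ccncc4)c23)s1` gives 28900 nM in a functional assay on HepG2 cells (Homo sapiens) for antiproliferative activity, read by MTT assay, with a stated time of 48 h (on this read-out lower numbers stand for stronger inhibition and higher numbers for weaker inhibition), the highest of the two numbers shown so far; the nearest is compound 1 `COc1ccc(NC(=O)Nc2nnc(Sc3ncnc4scc(-c5ccncc5)c34)s2)cc1`, which gives 14600 nM in this assay, and the two lie within the scatter of each other, as a 2.0-fold higher number from compound 1 to compound 2 (0.30 log units; within the scatter) shows. That single measured step, a change of the substituent on the same six-membered aromatic ring, is the only one that bears on the next change and it produced no movement beyond the scatter.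

Compound 3 `O=C(Nc1ccc(Cl)c(C(F)(F)F)c1)Nc1nnc(Sc2ncnc3scc(-c4ccncc4)c23)s1` is the not yet measured member; it differs from compound 2 by trifluoromethyl in place of hydrogen on an aromatic carbon. Among the measured compounds shown here, no measured step adds a trifluoromethyl group anywhere, so the expectation rests on the lone step from compound 1 to compound 2 alone. Compound 3 is expected to sit near compound 2, with a 1.2-fold lower number from compound 2 to compound 3 (0.06 log units; within the scatter) not beyond the scatter; the estimate for compound 3 is 25000 nM, with a range from 9000 nM to 70000 nM.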

Compound 3, half-maximal inhibitory concentration: 45300 nM
For compound 3 the middle estimate is 1.8-fold (0.26 log units) below the measured one; low and high end bracket the measured number.
By their numbers in this assay, from the lowest: compounds 1, 2 and 3 (each within the scatter of the next, the first and the last beyond it).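

Trifluoromethyl on the aromatic carbon ortho to a chloro group and meta to a large group gives a 1.6-fold higher number from compound 2 to compound 3 (0.20 log units; within the scatter) in this assay and so brings no shift that can be told from the scatter at this position. Among the compounds shown here, the wider change, 4-chloro-3-(trifluoromethyl)phenyl in place of 4-methoxyphenyl on the urea side of the core, gives a 3.1-fold higher number from compound 1 to compound 3 (0.49 log units; beyond the scatter) and is the first step to pass the scatter, though only modestly. No measurement at hand accounts for either step.

On these data alone, whether an amine, a carboxylic acid or a longer chain on this same carbon would move the number beyond the scatter remains open. Also open, as far as these compounds go, is what trifluoromethyl does on this ring when no chloro group is present.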